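Ethyl Ester of a Cell-Growth Inhibitor Scaffold

A few compounds are considered here, and "the series" means these few. Any claim that something is new, unique, unknown or untested is made for them only; others in the source may bear on it.

Compound 1 `O=C(O)/C=C/c1ccncc1-c1ccc2cc[nH]c2c1` was tested in a functional assay on A549 cells (Homo sapiens) for inhibition, read by sulforhodamine B assay, with a stated time of 72 h; a lower number here means a stronger inhibitor of growth, a higher number a weaker inhibitor of growth. In this assay compound 1 gives > 10000 nM, which is a limit of the assay rather than a measured number. Compound 2 `Cn1ccc2cc(-c3cnccc3/C=C/C(=O)O)ccc21` shares the same core but carries a methyl group on the ring nitrogen of its bicyclic part. In this assay compound 2 gives > 10000 nM, again a limit and not a number. Both values shown therefore sit at the same boundary (the limit of > 10000 nM in this assay, at which 2 of the 2 values shown sit), so neither compound has shown growth inhibition within the range the assay can report.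

Compound 3 `CCOC(=O)/C=C/c1ccncc1-c1ccc2cc[nH]c2c1` has not yet been measured. It differs from compound 1 in one place: ethyl in place of hydrogen on an oxygen next to a carbonyl group. Among the compounds with values here, no measured step is available to guide the size of this change, so the expected effect rests on the structures alone. A modest gain is expected, amounting to an at least 1.2-fold lower number from compound 1 to compound 3 (0.09 log units; that floor lies within the scatter), though it may well remain at the limit. For compound 3 the estimate in this assay is 8000 nM, within a range from 2000 nM to 30000 nM.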

Compound 3, concentration for 50% growth inhibition: 5740 nM
Compound 3: the middle estimate sits 1.4-fold (0.14 log units) above what was measured; low and high end bracket the measured number.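

Putting ethyl in place of hydrogen on this oxygen gives a number inside the reportable range of this assay, which neither earlier compound did. On these data alone, the step is an at least 1.7-fold lower number from compound 1 to compound 3 (0.24 log units; that floor lies within the scatter), and as one end of it is a limit, its full size stays unknown and the printed floor alone does not clear the usual scatter. Compound 3 therefore provides the only actual number of the three, while the other two stay at a shared boundary: the limit of > 10000 nM in this assay, at which 2 of the 3 values shown sit.

As far as these compounds go, it remains open whether ethyl is special at this position, or whether a methyl group, a longer chain or an amide in place of the ester would serve equally well. From the compounds shown here alone, it is also open how an ethyl ester would behave on compound 2, with its methyl group on the ring nitrogen.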